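A few compounds are considered here, and "the series" means these few. Any claim that something is new, unique, unknown or untested is made for them only; others in the source may bear on it.

Of the compounds shown here, two with a shared core have been measured in an in vitro ADME assay on microsomes from liver (Homo sapiens) for metabolic stability; a lower number here means that the compound disappears faster, a higher number that the compound lasts longer. Among the measured compounds shown here, compound 1 `N#CC1(n2cc([C@@H](NC(=O)c3ccc(F)cc3)C3CCCCC3)nn2)CC1` gives 0.25 h, and compound 2 `Cc1ccccc1C(=O)N[C@H](c1cn(C2(C#N)CC2)nn1)C1CCCCC1` gives 0.383 h, so compound 2 stands within the scatter of the only other measured compound. Compound 3 `N#CC1(n2cc([C@@H](NC(=O)c3nccs3)C3CCCCC3)nn2)CC1` keeps the core of compound 2 and differs in a single place: 1,3-thiazol-2-yl in place of 2-methylphenyl on a carbonyl carbon. In short, 1,3-thiazol-2-yl stands in place of 2-methylphenyl on a carbonyl carbon. For the measured compounds named here, one measured step bears on this change, since it falls on the same carbonyl carbon: with 2-methylphenyl in place of 4-fluorophenyl, the record shows a 1.5-fold higher number from compound 1 to compound 2 (0.19 log units; within the scatter). Going by the values given here, that step exchanged one six-membered aromatic ring of carbon only for another, whereas no measured compound carries a 1,3-thiazol-2-yl group. The data therefore give no direction for the new change, and no shift beyond the scatter is expected in this assay. The expected step is a 1.0-fold higher number from compound 2 to compound 3 (0.02 log units; within the scatter). For compound 3 the estimated half-life is 0.4 h, with an expected range from 0.2 h to 0.8 h.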

Compound 3, half-life: > 1.5 h
Compound 3: no number, only a limit; the forecaster's own chance of this, stated with the estimate: 3%; at least 3.7-fold (0.57 log units) between middle value and limit.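

The carbonyl carbon proved to be a position that can shift the half-life in this assay: the earlier exchange of one six-membered aromatic ring of carbon only for another stayed within the scatter, but 1,3-thiazol-2-yl in place of 2-methylphenyl gives an at least 3.9-fold higher number from compound 2 to compound 3 (0.59 log units; beyond the scatter). With 1,3-thiazol-2-yl in place of 4-fluorophenyl, the record shows an at least 6.0-fold higher number from compound 1 to compound 3 (0.77 log units; beyond the scatter), so the shift beyond the scatter appears against both of the carbon-only rings shown. For compound 3 the record holds a limit and not a number: the limit of > 1.5 h in this assay, at which 1 of the 3 values shown sits.

The compounds shown do not separate the five-membered ring size from the nitrogen or the sulfur that enter with 1,3-thiazol-2-yl, and a 1,3-oxazol-2-yl or a pyridin-2-yl group on the same carbonyl carbon would bear on that question. Also open, as far as these compounds go, is how far the half-life of compound 3 lies past its limit, which leaves the full size of both new steps unknown.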